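The compounds below may be only part of what the source reports. "The series", "measured", "known", "first", "only" and "open" are said of these compounds alone.

For the measured compounds named here, in an assay on isolated protein for binding affinity to leukotriene B4 receptor 1 (Homo sapiens), tested at 1 uM (on this read-out lower numbers stand for less inhibition and higher numbers for more inhibition at the one concentration tested (going by the name of the read-out)), compound 3 `CCCc1cc(C(C)=O)c(O)cc1OCCCCC(=O)O` gives 0%, the lowest of the three numbers measured so far. Compound 1 `CCCc1cc(C(C)=O)c(O)cc1OCCCCC#N` gives 37% and compound 2 `CCc1cc(C(C)=O)c(O)cc1OCCCCC(C)(C)C#N` gives 30%, and both stand beyond the scatter above compound 3. Going by the values given here, the one measured step that reaches compound 3 is a number 37 percentage points lower from compound 1 to compound 3 (beyond the scatter): the compound with carboxy at the chain end reads far lower than its cyano counterpart.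

Compound 4 `CCCc1cc(C(C)=O)c(O)cc1OCCCCCC(=O)O` differs from compound 3 in a single place: carboxymethyl in place of carboxy on a saturated chain carbon, four bonds along the chain from an oxygen on an aromatic ring. Among the compounds with values here, no measured pair shows what one added chain carbon ahead of a carboxy group does. Within the data shown here, compound 2 carries a longer chain than compound 1, but its chain ends in cyano and the two compounds also differ in the ring substituent, so that pair gives no clean step and only its two values can be noted. Among the measured compounds shown here, the only measured bearing on compound 4 is therefore that compound 3, the carboxy compound, sits at zero, and compound 4 keeps a carboxy end on its chain.

The step is expected to be a number 8 percentage points higher from compound 3 to compound 4 (within the scatter), within the scatter. In this assay compound 4 is estimated at 8%, with a range from 0% to 30%.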

Compound 4, a percentage reported as inhibition, at one concentration (the size of the read-out at that concentration, not a potency): 24%
For compound 4 the middle estimate is 16 percentage points below the measured one, and the stated range covers the measured number.
By their numbers in this assay, from the lowest: compound 3; then compounds 4, 2 and 1 (each within the scatter of the next, the first and the last beyond it).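

In this assay, carboxymethyl in place of carboxy on this saturated chain carbon, four bonds along the chain from an oxygen on an aromatic ring, gives a number 24 percentage points higher from compound 3 to compound 4 (beyond the scatter) and so lifts the reading clear of the floor set by the shorter acid. A carboxy end therefore does not by itself abolish the inhibition seen at the tested concentration, and the chain that carries it also matters for the number. Even so, carboxymethyl does not fully match the nitrile, since the change from cyano to carboxymethyl at this place gives a number 13 percentage points lower from compound 1 to compound 4 (beyond the scatter), and nothing available here accounts for either difference.

Going by these compounds, it remains open whether 2-carboxyethyl, 3-carboxypropyl or 4-carboxybutyl at this place would carry the number further up, hold it level or bring it down again. On these data alone, it is equally open how a primary amide, a tetrazole or an ester at the end of the chain would read against the acids and the nitrile on the shared core.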